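This account rests on a few compounds, and the source may have more. Where it says the series, first, only, none or still open, it means among the compounds named here.

Compound 2 `CC(=O)Oc1ccc(-c2ccc(F)cc2F)cc1C(=O)Nc1cccc(C)c1` carries (3-methylphenyl)amino in place of hydroxy on a carbonyl carbon relative to compound 1 `CC(=O)Oc1ccc(-c2ccc(F)cc2F)cc1C(=O)O`. In a functional assay on the whole organism (Ear) for inhibition, with Mus musculus as the target, at a dose of 40 mg/kg by the oral route (a lower number here means less inhibition, a higher number more inhibition at the dose given (going by the name of the read-out)), compound 2 gives 12.8%, while compound 1 gives 13.7%; the step of a number 0.9 percentage points lower from compound 1 to compound 2 (within the scatter) lies within the scatter, so the two numbers cannot be told apart. Compound 3 `CC(=O)Oc1ccc(-c2ccc(F)cc2F)cc1C(=O)Nc1ccc(C)cc1` differs from compound 2 by 4-methylphenyl in place of 3-methylphenyl on an amide-type nitrogen. Among the measured compounds shown here, no measured step compares 3-methylphenyl with 4-methylphenyl, and the single step known is within the scatter. Therefore no shift beyond the scatter is expected. Compound 3 is estimated at 13%, between 0% and 30%. The expected step is a number 0.2 percentage points higher from compound 2 to compound 3 (within the scatter).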

Compound 3, a percentage reported as inhibition, in the whole organism at one dose (the size of the read-out at that dose, not a potency): 36.4%
For compound 3 the middle estimate is 23.4 percentage points below the measured one; the whole stated range lies below it.
By their numbers in this assay, from the lowest: compounds 2 and 1 (each within the scatter of the next); then compound 3.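

At the amide-type nitrogen, the position of the methyl on the phenyl ring matters in this assay: a number 23.6 percentage points higher from compound 2 to compound 3 (beyond the scatter) is a change between 3-methylphenyl and 4-methylphenyl, two groups with the same atoms joined differently. Replacing hydroxy on the carbonyl carbon with (3-methylphenyl)amino stayed within the scatter, whereas with (4-methylphenyl)amino the result is a number 22.7 percentage points higher from compound 1 to compound 3 (beyond the scatter), so the outcome of that replacement depends on the group carried. No measured evidence bears on the reason for this difference.

Open, as far as these compounds go, is whether 2-methylphenyl, 4-ethylphenyl or 4-chlorophenyl on the same nitrogen would match 4-methylphenyl. Also open, from the compounds shown here alone, is whether the gain persists when the amide hydrogen is replaced by a methyl group.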